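The source may hold more compounds than are shown below. What is called first, only, known or untested is meant among the compounds shown, and "the series" means these compounds.

Compound 3 `O=C(Nc1ccc(O)cc1)C1c2ccccc2CCN1C(=O)c1ccc(Cl)cc1` and compound 1 `COc1ccc(NC(=O)C2c3ccccc3CCN2C(=O)c2ccc(Cl)cc2)cc1` share one core and differ only in methyl in place of hydrogen on an oxygen on an aromatic ring. In a functional assay on NUGC-3 cells (Homo sapiens) for inhibition, read by sulforhodamine B assay, with a stated time of 48 h (on this read-out lower numbers stand for stronger inhibition of growth and higher numbers for weaker inhibition of growth), compound 1 gives 3630 nM. Compound 3 reaches only the limit of this assay, reported as > 10000 nM. The step is therefore known only as a bound, an at least 2.7-fold lower number from compound 3 to compound 1 (0.44 log units; beyond the scatter), because of the limit of > 10000 nM in this assay, at which 2 of the 3 values shown sit. Compound 2 `O=C(Nc1ccccc1O)c1nccc2ccccc12` rests on a different core; the difference between the two cores is not broken down here. In this assay compound 2 also stops at the limit, reported as > 10000 nM. Compound 4 `COc1ccccc1NC(=O)c1nccc2ccccc12` arises from compound 2 by methyl in place of hydrogen on an oxygen on an aromatic ring, the same change as from compound 3 to compound 1. The expected step here is an at least 1.2-fold lower number from compound 2 to compound 4 (0.09 log units; that floor lies within the scatter), resting on an at least 2.7-fold lower number from compound 3 to compound 1 (0.44 log units; beyond the scatter). Compound 4 is accordingly estimated at 8000 nM, with a range from 2500 nM to 25000 nM.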

Compound 4, concentration for 50% growth inhibition: > 10000 nM
Compound 4: no number, only a limit; the forecaster's own chance of this, stated with the estimate: 45%; at least 1.2-fold (0.09 log units) between middle value and limit.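

Compound 2 and compound 4 both stop at a limit, so the step between them cannot be read: the limit of > 10000 nM in this assay, at which 3 of the 4 values shown sit. The compounds shown leave open whether hydroxy to methoxy changes growth inhibition on this core in this assay.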